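Chain length and carboxylesterase inhibition by trifluoromethyl hydrates

The source may report more compounds than this note shows. Statements on the series, on what has been measured and on what is new or still open speak of the compounds shown alone.

Compound 1, `CCCCCC[S+]([O-])CC(O)(O)C(F)(F)F`: 3.31 nM
Compound 2, `CCCCCCCCCCCCS(=O)(=O)CC(O)(O)C(F)(F)F`: 0.398 nM

Going by the values given here, in an assay on isolated protein for inhibition of liver carboxylesterase 1 (Homo sapiens), with a stated time of 24 h (a lower number here means a stronger inhibitor, a higher number a weaker inhibitor), compound 1 gives 3.31 nM, the higher of the two numbers measured so far, while compound 2 gives 0.398 nM, a lower number that lies beyond the usual scatter. Compound 3, `CCCCCCCC[S+]([O-])CC(O)(O)C(F)(F)F`, differs from compound 1 by ethyl in place of hydrogen on a saturated chain carbon, six bonds along the chain from a sulfur. Among the compounds with values here, no measured pair shows this change, so its effect is not known; a lower number, that is a stronger inhibitor, is expected for compound 3, probably by a step beyond the scatter. Compound 3 is therefore expected to give about 1.2 nM, in the range 0.4 nM to 3.5 nM, which corresponds to an estimated step of a 2.8-fold lower number from compound 1 to compound 3 (0.44 log units; beyond the scatter).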

Compound 3, inhibition constant: 0.603 nM
The estimate for compound 3 lay 2.0-fold (0.30 log units) above the measured number; measured number inside the range.
By their numbers in this assay, from the lowest: compounds 2 and 3 (each within the scatter of the next); then compound 1.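

In this assay, ethyl in place of hydrogen on a saturated chain carbon, six bonds along the chain from a sulfur, gives a 5.5-fold lower number from compound 1 to compound 3 (0.74 log units; beyond the scatter) and so lies beyond the scatter. Going by these compounds alone, this is the first pair differing in one place, and it shows that this position accepts the added carbons with stronger inhibition. Nothing available accounts for the size of this step.

Going by these compounds, it remains open whether a longer chain on the same core would lower the number further. On these data alone, the effect of an amine or a carboxylic acid at the chain end also remains open.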